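Shortening the amide chain of an aminophenol

The compounds below may be only part of what the source reports. "The series", "measured", "known", "first", "only" and "open" are said of these compounds alone.

Of the compounds shown here, two sharing a phenol core have been measured in a functional assay on DU-145 cells (Homo sapiens) for inhibition, with a stated time of 68 h, tested at 4 uM; a higher number here means more inhibition at the concentration tested (going by the name of the read-out), a lower number less inhibition. Compound 1, `CCCCCCCCCCNc1ccc(O)cc1`, carries a long chain joined to the ring through an amine; in this assay compound 1 gives 66%. Compound 2, `CCCCCCCCCCCC(=O)Nc1ccc(O)cc1`, carries its chain through an amide instead; in this assay compound 2 gives 41%, the lower of the two numbers, and the gap to compound 1 lies beyond the usual scatter. For the measured compounds named here, no pair of measured compounds differs in just one place, so there is no single measured step to lean on.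

Compound 3, `CCCCCCCCCC(=O)Nc1ccc(O)cc1`, is compound 2 with a shorter chain: hydrogen in place of ethyl on a saturated chain carbon, nine bonds along the chain from a carbonyl carbon. The change sits on a saturated chain carbon, nine bonds along the chain from the carbonyl carbon, and removes no donor or acceptor. With nothing measured to show how chain length alone matters here, the step is expected to be small, likely within the scatter: a number 1 percentage points lower from compound 2 to compound 3 (within the scatter). Compound 3 is therefore estimated at 40%, with a plausible range from 20% to 60%.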

Compound 3, a percentage reported as inhibition, at one concentration (the size of the read-out at that concentration, not a potency): 51%
Estimate against measurement, compound 3: 11 percentage points below, within the range that was stated.
By their numbers in this assay, from the lowest: compounds 2 and 3 (each within the scatter of the next); then compound 1.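

For the compounds shown here, measured in this assay the replacement of ethyl by hydrogen on a saturated chain carbon, nine bonds along the chain from a carbonyl carbon, gives a number 10 percentage points higher from compound 2 to compound 3 (within the scatter) and so supplies the first measured step that changes only one place. This change removes no hydrogen-bond donor or acceptor, and on this single step its effect cannot be told apart from the ordinary variation between repeated measurements, so compound 2 and compound 3 cannot be ranked against each other. Nothing among the available data accounts for the size of this step.

A single step within the scatter cannot show whether chain length matters over a wider span, so a longer chain, or a chain of this kind ending in a carboxylic acid or an amine, remains an open case. It is also unknown whether the same shortening would give a similar result on the amine-linked chain of compound 1, where the link to the shared core differs from that in compound 2 and compound 3.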